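From phenethyl to 4-chlorophenyl on a sulfur

The source may report more compounds than this note shows. Statements on the series, on what has been measured and on what is new or still open speak of the compounds shown alone.

- Compound 1 `CCc1ccc(SCc2ccc(C(=O)Nc3ccccc3N)cc2)cc1` gives 40.7%
- Compound 2 `Nc1ccccc1NC(=O)c1ccc(CSCCc2ccccc2)cc1` gives 30.5%

In a functional assay on HCT-116 cells (Homo sapiens) for inhibition, read by CCK-8 assay, with a stated time of 72 h, tested at 2 uM (a higher number here means more inhibition of growth at the concentration tested, a lower number less inhibition of growth), compound 2 has the lower of the two measured numbers, at 30.5% in that test. The next compound, compound 3 `Nc1ccccc1NC(=O)c1ccc(CSc2ccc(Cl)cc2)cc1`, has not yet been measured. It has 4-chlorophenyl in place of phenethyl on a sulfur and keeps the rest of compound 2 unchanged. For the measured compounds named here, only one measured step bears on this change: a number 10.2 percentage points lower from compound 1 to compound 2 (beyond the scatter), a modest drop beyond the scatter, with phenethyl in place of 4-ethylphenyl on a sulfur. Compound 3 again has a substituted phenyl group on that sulfur, as compound 1 does, so a rise of similar size seems likely. Going by the values given here, no measured pair shows how chlorine compares with ethyl here. The expected change is a number 9.5 percentage points higher from compound 2 to compound 3 (within the scatter) in this assay, an upward step. For compound 3 the estimated value is 40%, with an expected range from 28% to 54% overall.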

Compound 3, percent growth inhibition at one concentration: 17.5%
Estimate against measurement, compound 3: 22.5 percentage points above, outside the stated range (below it).
By their numbers in this assay, from the lowest: compound 3; then compound 2; then compound 1.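

In this assay, 4-chlorophenyl in place of phenethyl on the sulfur gives a number 13 percentage points lower from compound 2 to compound 3 (beyond the scatter) and shows that a substituted phenyl group on that sulfur does not by itself give the higher number. For the compounds shown here, the first direct comparison of chloro with ethyl on the aromatic carbon gives a number 23.2 percentage points lower from compound 1 to compound 3 (beyond the scatter) and shows that the choice of group on that ring changes the result. Nothing available gives a reason for either drop.

Still open, as far as these compounds go, is where a methoxy group, an amine or a carboxylic acid in place of the chloro would fall relative to compound 1 and compound 3. It is equally unknown how a benzyl group or a longer chain on the sulfur would compare with the phenethyl of compound 2.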